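The source may report more compounds than this note shows. Statements on the series, on what has been measured and on what is new or still open speak of the compounds shown alone.

Working notes on the selenium series.

Compound 1 `CCCCC[Se]c1nc(NCc2ccccc2)c2ccccc2n1` in a functional assay on HTB-54 cells (Homo sapiens) for cytotoxicity, read by MTT assay, with a stated time of 72 h (a higher number here means a weaker inhibitor of growth, a lower number a stronger inhibitor of growth), gives 81100 nM. Compound 3 `C[Se]c1nc(NCc2ccccc2)c2ccccc2n1` returns only a limit of this assay, > 100000 nM. The change between them is hydrogen in place of butyl on a saturated chain carbon bound to a selenium atom and it gives an at least 1.2-fold higher number from compound 1 to compound 3 (0.09 log units; that floor lies within the scatter); the size of that step cannot be pinned down because of the limit of > 100000 nM in this assay, at which 1 of the 3 values shown sits.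

Compound 2 `CCCCC[Se]c1nc(N)c2cccnc2n1` in this assay gives 51000 nM. Its core differs from that of compound 1, but the difference between the two cores is not broken down here. The two values of compound 1 and compound 2 sit within the usual scatter of each other.

Compound 4 `C[Se]c1nc(N)c2cccnc2n1` has not yet been measured in this assay. It stands to compound 2 as compound 3 stands to compound 1: the change is hydrogen in place of butyl on a saturated chain carbon bound to a selenium atom, the same change in the same place. On the strength of the step seen from compound 1 to compound 3, compound 4 is expected to give a weaker number than compound 2, with the estimated step of a 1.8-fold higher number from compound 2 to compound 4 (0.25 log units; within the scatter). Compound 4 is thus estimated at 90000 nM, expected between 50000 nM and 160000 nM, with a real chance that only a limit is reported.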

Compound 4, concentration for total growth inhibition: > 100000 nM
Compound 4 was reported as a limit; the forecaster's own chance of this, stated with the estimate: 45%; middle value at least 1.1-fold (0.04 log units) away from the limit.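

In this assay compound 4 gives > 100000 nM, which is a limit of the assay and not a number. The change from pentyl to methyl on the core of compound 2 gives an at least 1.9-fold higher number from compound 2 to compound 4 (0.29 log units; that floor lies within the scatter), and set beside the same change on the core of compound 1 it reads: the same change on two cores in this assay, an at least 1.2-fold higher number (0.09 log units; that floor lies within the scatter) from compound 1 to compound 3 and an at least 1.9-fold higher number (0.29 log units; that floor lies within the scatter) from compound 2 to compound 4; the limit leaves it open whether they differ The result fits a change that carries from one core to the other, but it does not show that the change weakens growth inhibition on either core or that its size is shared, and neither step has a measured size: the limit of > 100000 nM in this assay, at which 2 of the 4 values shown sit.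

Open, on these data alone, is what a shorter chain such as ethyl or propyl gives in place of pentyl on the selenium atom, and whether such a compound would return a number rather than a limit on either core. Also open, as far as these compounds go, is whether a longer chain such as octyl, or a pentyl chain carrying an amine or a carboxylic acid, gives a step beyond the scatter in this assay.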